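Trimming a Pentyl Chain from a Flavanone Core

The source may hold more compounds than are shown below. What is called first, only, known or untested is meant among the compounds shown, and "the series" means these compounds.

Of the compounds shown here, two with a shared core have been tested in a functional assay on MCF7 cells (Homo sapiens) for antiproliferative activity, read by sulforhodamine B assay, with a stated time of 72 h; a lower number here means a stronger inhibitor, a higher number a weaker inhibitor. Compound 1 `CCCCCOc1ccc([C@@H]2CC(=O)c3c(OC)cc(OCCCCC)c(CC=C(C)C)c3O2)cc1` gives 7.1 ug/mL in this assay. For the measured compounds named here, compound 2 `COc1ccc(C2CC(=O)c3c(O)cc(OC)c(CC=C(C)C)c3O2)cc1` gives 36.9 ug/mL in this assay, which is a higher number than that of compound 1, and the gap between the two lies beyond the usual scatter, so compound 1 stands as the lower of the two numbers measured so far.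

Compound 3 `CCCCCOc1cc(OC)c2c(c1CC=C(C)C)O[C@H](c1ccc(O)cc1)CC2=O` has not yet been measured in this assay. It differs from compound 1 in a single place: hydrogen in place of pentyl on an oxygen on an aromatic ring. Cut one bond further out, the change reads pentyloxy to hydroxy, or 4-(pentyloxy)phenyl to 4-hydroxyphenyl. Going by the values given here, no pair of measured compounds shows this exact change, so its effect is not known here.

Compound 2, which carries smaller groups than compound 1, gives the higher number, and the loss of a whole pentyl chain is a substantial change. For compound 3 the expectation is therefore a weaker result than compound 1, with a step of a 2.3-fold higher number from compound 1 to compound 3 (0.35 log units; beyond the scatter) in this assay. Compound 3 is estimated at 16 ug/mL, within a range of 6 ug/mL to 45 ug/mL.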

Compound 3, concentration for 50% inhibition: 8.3 ug/mL
For compound 3 the middle estimate is 1.9-fold (0.29 log units) above the measured one; measured number inside the range.
By their numbers in this assay, from the lowest: compounds 1 and 3 (each within the scatter of the next); then compound 2.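

In this assay, replacing the pentyl on an oxygen on an aromatic ring with hydrogen gives a 1.2-fold higher number from compound 1 to compound 3 (0.07 log units; within the scatter). This single change turns 4-(pentyloxy)phenyl into 4-hydroxyphenyl and removes a chain of five carbons, yet compound 1 and compound 3 cannot be told apart in this assay, so this pair gives no sign that the chain at this position matters for the antiproliferative read-out. Nothing measured here explains why the two compounds match, and no outside evidence bears on it.

This pair cannot show whether a longer chain such as octyl on the same oxygen, or a chain ending in an amine or a carboxylic acid, would also leave the number unmoved. As far as these compounds go, compound 1 and compound 3 also both keep their other pentyloxy group, so what that second chain contributes remains open.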